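The source may hold more compounds than are shown below. What is called first, only, known or untested is meant among the compounds shown, and "the series" means these compounds.

In a functional assay on A549 cells (Homo sapiens) for antiproliferative activity, read by MTT assay, with a stated time of 72 h (on this read-out lower numbers stand for stronger inhibition and higher numbers for weaker inhibition), three compounds share one core and differ only in the group on a nitrogen on an aromatic ring. Compound 1 `CN(C(=O)C(C)(C)C)c1ccc2[nH]c(-c3n[nH]c4ccccc34)cc2n1` gives 24400 nM, compound 2 `CN(C(=O)c1ccc(F)cc1)c1ccc2[nH]c(-c3n[nH]c4ccccc34)cc2n1` gives 9650 nM, and compound 3 `CN(c1ccc2[nH]c(-c3n[nH]c4ccccc34)cc2n1)S(=O)(=O)c1ccccc1` gives 14000 nM. Compound 3 thus has the second highest of the three numbers, with the gap a 1.5-fold higher number from compound 2 to compound 3 (0.16 log units; within the scatter) and the gap a 1.7-fold lower number from compound 1 to compound 3 (0.24 log units; within the scatter) both within the scatter, so no order among the three can be claimed. Compound 4 `COc1ccc(S(=O)(=O)N(C)c2ccc3[nH]c(-c4n[nH]c5ccccc45)cc3n2)cc1OC` differs from compound 3 in one place: 3,4-dimethoxyphenyl in place of phenyl on a sulfonyl sulfur. Among the compounds with values here, no measured pair changes the ring on the sulfonyl sulfur, so the expectation rests on indirect evidence. Within the data shown here, the one step that swaps an aryl group for another group on a carbonyl carbon, a 2.5-fold lower number from compound 1 to compound 2 (0.40 log units; beyond the scatter), was modest, and the two steps that replace the whole group on the nitrogen left the numbers within the scatter. Adding two methoxy groups to an aromatic ring that is already tolerated is therefore expected to move the number little; the expected step is a 1.4-fold lower number from compound 3 to compound 4 (0.15 log units; within the scatter), within the scatter. Compound 4 is estimated at 10000 nM, with a range from 3500 nM to 30000 nM.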

Compound 4, half-maximal inhibitory concentration: > 50000 nM
Compound 4 ended at the assay's limit; the forecaster's own chance of this, stated with the estimate: 5%; middle value at least 5.0-fold (0.69 log units) from the limit.
By their numbers in this assay, from the lowest: compounds 2, 3 and 1 (each within the scatter of the next, the first and the last beyond it). At a limit, above all of these: compound 4.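

Within the data shown here, the ring on the sulfonyl sulfur is less forgiving than the earlier compounds suggested: in this assay, 3,4-dimethoxyphenyl in place of phenyl gives an at least 3.5-fold higher number from compound 3 to compound 4 (0.55 log units; beyond the scatter). The value of compound 4, > 50000 nM, is a limit of the assay and not a number: the limit of > 50000 nM in this assay, at which 1 of the 4 values shown sits.

Among these compounds, replacing the whole group on the nitrogen had left the numbers within the scatter, as a 1.7-fold lower number from compound 1 to compound 3 (0.24 log units; within the scatter) and a 1.5-fold higher number from compound 2 to compound 3 (0.16 log units; within the scatter) show, whereas this change keeps the aromatic ring on the sulfonyl sulfur and still moves the number beyond the scatter, so the substituents on that ring matter more than the earlier steps could reveal.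

From the compounds shown here alone, what lies behind this step cannot be told from these compounds, and it remains open whether the loss comes from the methoxy groups themselves or from any addition to the phenyl ring. Going by these compounds, how a phenyl ring carrying a single methoxy, a chlorine or a methyl group would behave on the sulfonyl sulfur is also open, as is the effect of an amine on that ring.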